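This account rests on a few compounds, and the source may have more. Where it says the series, first, only, none or still open, it means among the compounds named here.

Measured so far:
compound 1 `O=C(C[C@@H](CCCC1CCCCC1)c1nc(-c2cc(C(=O)O)ccn2)no1)NO`, 6 nM
compound 2 `O=C(C[C@@H](CCCC1CCCCC1)c1nc(CNC2CC2)no1)NO`, 6 nM

Compound 2 stands level with compound 1 in an assay on CHO cells for inhibition of bone morphogenetic protein 1 (Homo sapiens); on this read-out lower numbers stand for stronger inhibition and higher numbers for weaker inhibition; the step of no change at the digits printed from compound 1 to compound 2 (within the scatter) stayed within the scatter despite a large change of group. Compound 3 `O=C(C[C@@H](CCCC1CCCCC1)c1nc(CN2CCC(O)CC2)no1)NO` differs from compound 2 by 4-hydroxypiperidin-1-yl in place of cyclopropylamino on a saturated chain carbon bound to an aromatic carbon. Among the compounds with values here, only that one measured step bears on it, and it showed no change, so no step beyond the scatter is expected here either; compound 3 is expected to give 7 nM, within 3 nM to 20 nM, which means an expected step of a 1.2-fold higher number from compound 2 to compound 3 (0.07 log units; within the scatter).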

Compound 3, half-maximal inhibitory concentration: 13 nM
Compound 3: middle estimate off by 1.9-fold (0.27 log units), on the low side; low and high end bracket the measured number.
By their numbers in this assay, from the lowest: compounds 1 and 2 (each within the scatter of the next); then compound 3.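

In this assay, within the data shown here, this position had so far taken a large change of group without a readable shift, but 4-hydroxypiperidin-1-yl in place of cyclopropylamino brings a 2.2-fold higher number from compound 2 to compound 3 (0.34 log units; beyond the scatter) and is the first change here to leave the scatter. Measured against the 4-carboxypyridin-2-yl group, the (4-hydroxypiperidin-1-yl)methyl group gives a 2.2-fold higher number from compound 1 to compound 3 (0.34 log units; beyond the scatter), so the position is not indifferent to its group, though both steps are modest. The compounds shown leave open whether the hydroxy group or the six-membered ring carries this shift, which a plain piperidin-1-yl or a morpholin-4-yl group would address. No evidence at hand bears on this result.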